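Piperidine amide series: neopentyl for isopropyl on the amide nitrogen

The source may hold more compounds than are shown below. What is called first, only, known or untested is meant among the compounds shown, and "the series" means these compounds.

Two compounds carry a result field in a functional assay on CHO cells for positive allosteric modulation of muscarinic acetylcholine receptor M5 (Homo sapiens), read by calcium flux; on this read-out higher numbers stand for larger maximal responses and lower numbers for smaller maximal responses. Compound 1 `CCN(Cc1ccccc1)C(=O)C1CCN(S(=O)(=O)c2ccccc2OC)CC1` has no result reported there; in this assay compound 1 carries the entry "not determined" (no result reported). Compound 2 `CC(C)N(Cc1ccccc1C(F)(F)F)C(=O)C1CCN(S(=O)(=O)c2ccc3[nH]ncc3c2)CC1` gives 54% in this assay, and it is the only number shown, so compound 2 stands alone as the sole reference point; nothing in these notes says how the series responds to any change yet.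

Compound 3 `CC(C)(C)CN(Cc1ccccc1C(F)(F)F)C(=O)C1CCN(S(=O)(=O)c2ccc3[nH]ncc3c2)CC1` is the next entry awaiting measurement. It differs from compound 2 in one place: neopentyl in place of isopropyl on an amide-type nitrogen. Going by the values given here, no measured pair in this set brackets a change of this kind, so the direction of the step is not anchored by data.

Expectation: the step from a number 4 percentage points lower from compound 2 to compound 3 (within the scatter) is estimated to stay within the usual scatter of this assay, with no clear direction. For compound 3 the estimated maximal response is 50%, with a range of 25% to 75%.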

Compound 3, largest response reached (reported as percent of maximum), in percent of the reference or control that the assay uses: 104%
The estimate for compound 3 lay 54 percentage points below the measured number, and the stated range ends below it.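

Going by these compounds alone, on the amide-type nitrogen, the maximal response in this assay proves sensitive to the alkyl group: neopentyl in place of isopropyl gives a number 50 percentage points higher from compound 2 to compound 3 (beyond the scatter) and provides the first readable step. Neither group carries a hydrogen-bond donor, a hydrogen-bond acceptor or a net charge, so a change confined to a saturated carbon group is enough for a step of this size. No available data bear on the reason for this step.

As far as these compounds go, this is a single pair, so whether the step carries over to other members remains open. From the compounds shown here alone, it is also open whether a straight pentyl chain, a cyclohexylmethyl group or a chain ending in an amine would behave like neopentyl, and thus whether chain length or branching matters here.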